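Compound 3 to compound 4: carboxy to carbamoyl

A few compounds are considered here, and "the series" means these few. Any claim that something is new, unique, unknown or untested is made for them only; others in the source may bear on it.

Values in a functional assay on HEL cells (Homo sapiens); a higher number here means that more compound is tolerated, a lower number that less compound is tolerated:
Compound 1 `COC(=O)NC1=CS(=O)(=O)O[C@@]12[C@@H](CO[Si](C)(C)C(C)(C)C)O[C@@H](n1cc(C)c(=O)n(C)c1=O)[C@@H]2O[Si](C)(C)C(C)(C)C`: > 200000 nM, a limit
Compound 2 `Cc1cn([C@@H]2O[C@H](CO[Si](C)(C)C(C)(C)C)[C@@]3(OS(=O)(=O)C=C3NCC(=O)C(=O)O)[C@H]2O[Si](C)(C)C(C)(C)C)c(=O)n(C)c1=O`: 146000 nM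
Compound 3 `Cc1cn([C@@H]2O[C@H](CO[Si](C)(C)C(C)(C)C)[C@@]3(OS(=O)(=O)C=C3NCCC(=O)O)[C@H]2O[Si](C)(C)C(C)(C)C)c(=O)n(C)c1=O`: 34000 nM

In this assay compound 3 has the lower of the two actual numbers, and compound 2 sits higher. Compound 4 `Cc1cn([C@@H]2O[C@H](CO[Si](C)(C)C(C)(C)C)[C@@]3(OS(=O)(=O)C=C3NCCC(N)=O)[C@H]2O[Si](C)(C)C(C)(C)C)c(=O)n(C)c1=O` carries amino in place of hydroxy on a carbonyl carbon. Among the compounds with values here, no measured step makes this exact change. The closest guides are a 4.3-fold lower number from compound 2 to compound 3 (0.63 log units; beyond the scatter) and an at least 5.8-fold lower number from compound 1 to compound 3 (0.76 log units; beyond the scatter), both of which change the same substituent. A step no larger than these is expected, more probably upward than downward. The expected step is a 1.6-fold higher number from compound 3 to compound 4 (0.21 log units; within the scatter). For compound 4 the estimated value is 55000 nM, with an expected range of 17000 nM to 170000 nM.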

Compound 4, half-maximal cytotoxic concentration: 14800 nM
Beside the measured number, compound 4's estimate is 3.7-fold (0.57 log units) above it, and the stated range ends above it.
By their numbers in this assay, from the lowest: compound 4; then compound 3; then compound 2. At a limit, above all of these: compound 1.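

In this assay, the end of the 2-carboxyethyl chain still moves the number: amino in place of hydroxy on a carbonyl carbon gives a 2.3-fold lower number from compound 3 to compound 4 (0.36 log units; beyond the scatter), with the chain itself unchanged. Set against the carboxycarbonyl-bearing chain, 2-carbamoylethyl gives a 9.9-fold lower number from compound 2 to compound 4 (0.99 log units; beyond the scatter), leaving compound 4 with the lowest number of the series. The step against the methoxycarbonyl group, an at least 13-fold lower number from compound 1 to compound 4 (1.13 log units; beyond the scatter), is a floor only, because its starting number is a limit: the limit of > 200000 nM in this assay, at which 1 of the 4 values shown sits.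

Open, going by these compounds, is whether a methyl ester or a methylamino group on this carbonyl carbon would follow carbamoyl or carboxy. Also open, on these data alone, is how a longer chain carrying the carbamoyl group would read.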